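The source may hold more compounds than are shown below. What is called first, only, known or untested is meant among the compounds shown, and "the series" means these compounds.

Of the compounds shown here, two that share one core have been measured so far in an ADME assay on microsomes from liver (Mus musculus) for pharmacokinetics, read by LC-MS, using NADPH, with stated times of 5 min, 15 min and 30 min, tested at 10 uM; a higher number here means faster removal of the compound, a lower number slower removal. Compound 1 `C[C@@H](c1ccc(NC(=O)N2CC(c3cncc(N)c3)C2)cc1)N1Cc2ccccc2C1=O` gives 158 mL.min-1.g-1, while compound 2 `C[C@H](NC(=O)C1CCOCC1)c1ccc(NC(=O)N2CC(c3cncc(N)c3)C2)cc1` gives 60.2 mL.min-1.g-1, the lower of the two numbers. Compound 3 `C[C@H](NC(=O)[C@@H]1CCCN1C)c1ccc(NC(=O)N2CC(c3cncc(N)c3)C2)cc1` differs from compound 2 in a single group: 1-methylpyrrolidin-2-yl in place of oxan-4-yl on a carbonyl carbon. In words, 1-methylpyrrolidin-2-yl stands in place of oxan-4-yl on a carbonyl carbon whose other neighbour is an amide-type nitrogen. A six-membered non-aromatic ring with an oxygen as its hetero atom thus gives way to a five-membered one with a nitrogen, and the new group brings a defined stereocentre.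

Within the data shown here, only one measured step offers any guide: a 2.6-fold lower number from compound 1 to compound 2 (0.42 log units; beyond the scatter), a modest change beyond the scatter. Among the measured compounds shown here, it involved a different swap, so it gives a rough idea of size but no direct precedent, and no measured compound carries the new group. The direction is therefore uncertain, but a small rise is the best guess, and the expected step is a 1.7-fold higher number from compound 2 to compound 3 (0.22 log units; within the scatter). Compound 3 is estimated at 100 mL.min-1.g-1, with an expected range from 40 mL.min-1.g-1 to 220 mL.min-1.g-1.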

Compound 3, intrinsic clearance in microsomes: 47.4 mL.min-1.g-1
Beside the measured number, compound 3's estimate is 2.1-fold (0.32 log units) above it, within the range that was stated.
By their numbers in this assay, from the lowest: compounds 3 and 2 (each within the scatter of the next); then compound 1.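

In this assay, 1-methylpyrrolidin-2-yl in place of oxan-4-yl on the carbonyl carbon gives a 1.3-fold lower number from compound 2 to compound 3 (0.10 log units; within the scatter), so this read-out does not separate the two rings at this position, even though the six-membered ring with its oxygen gives way to a five-membered ring with a nitrogen. The change from compound 1 gives a 3.3-fold lower number from compound 1 to compound 3 (0.52 log units; beyond the scatter), and with the earlier step this means that both compounds carrying a ring group on an amide carbonyl stand apart from compound 1, so the earlier shift is not tied to oxan-4-yl alone. The data at hand offer no measurement that explains why the two ring groups read alike.

On these data alone, it remains open whether the defined stereocentre of 1-methylpyrrolidin-2-yl matters, which only the opposite form of the same group could settle. As far as these compounds go, it also remains open whether the number would hold with a quite different group on this carbonyl carbon, such as a short open chain ending in an amine or a carboxylic acid, or with these same ring groups on another core.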